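Hydrazone series on HepG2: step from compound 2 to compound 4

This account rests on a few compounds, and the source may have more. Where it says the series, first, only, none or still open, it means among the compounds named here.

Measured compounds:
compound 1 `CN(C(=O)NC(=O)c1ccccc1F)c1nc(C(F)(F)F)c(C(=O)N/N=C/c2cc(C(F)(F)F)cc(C(F)(F)F)c2)s1` — 4.47 ug/mL
compound 2 `Cc1nc(N(C)C(=O)NC(=O)c2c(F)cccc2F)sc1C(=O)N/N=C/c1ccccc1` — 54.3 ug/mL
compound 3 `CN(C(=O)NC(=O)c1ccc(F)c(F)c1)c1nc(C(F)(F)F)c(C(=O)N/N=C/c2ccc([N+](=O)[O-])cc2)s1` — 6.23 ug/mL

The three compounds share a core and differ in the acyl group on the urea, the substituent on the core and the aryl part of the hydrazone. In a functional assay on HepG2 cells (Homo sapiens) for inhibition, read by MTT assay, with a stated time of 72 h (a lower number here means a stronger inhibitor, a higher number a weaker inhibitor), compound 2 gives 54.3 ug/mL, the highest of the three numbers. Compound 3 gives 6.23 ug/mL and compound 1 gives 4.47 ug/mL; both of these gaps to compound 2 lie beyond the scatter, so compound 2 is the weakest inhibitor of the three as measured.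

Compound 4 `COc1cc(/C=N/NC(=O)c2sc(N(C)C(=O)NC(=O)c3c(F)cccc3F)nc2C)cc(OC)c1OC` has not been measured in this assay. It differs from compound 2 in one place: 3,4,5-trimethoxyphenyl in place of phenyl on a carbon with a double bond to nitrogen. Going by the values given here, no measured pair shows this change on its own, so its effect is not known from these data. The two more potent compounds both carry a substituted aryl group on the hydrazone carbon, whereas compound 2 carries plain phenyl; on that thin basis a modest decrease in number is expected, with wide uncertainty. The step from compound 2 to compound 4 is estimated at a 2.2-fold lower number from compound 2 to compound 4 (0.34 log units; beyond the scatter). Compound 4 is expected to give about 25 ug/mL in this assay, within a range of 8 ug/mL to 80 ug/mL.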

Compound 4, half-maximal inhibitory concentration: > 100 ug/mL
Compound 4 gave a limit, no number; the forecaster's own chance of this, stated with the estimate: 10%; middle value at least 4.0-fold (0.60 log units) from the limit.
By their numbers in this assay, from the lowest: compounds 1 and 3 (each within the scatter of the next); then compound 2. At a limit, above all of these: compound 4.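

In this assay, going by these compounds alone, 3,4,5-trimethoxyphenyl in place of phenyl on the carbon with a double bond to nitrogen gives the only single-place step in this set: an at least 1.8-fold higher number from compound 2 to compound 4 (0.26 log units; that floor lies within the scatter). Compound 4 gives > 100 ug/mL, which is a limit of the assay and not a number: the limit of > 100 ug/mL in this assay, at which 1 of the 4 values shown sits. On this one pair, 3,4,5-trimethoxyphenyl brings no lower number than phenyl, although the step is only a floor and cannot show how far the true value lies from that of compound 2.

Open, from the compounds shown here alone, is whether a single hydroxy group or a dimethylamino group on the phenyl at this place would give a lower number. Also open, going by these compounds, is whether 3,4,5-trimethoxyphenyl would give a similar step on the core of compound 1, which carries trifluoromethyl in place of methyl.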